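Swapping an acetyl for a dimethylamino group on a pyridine-linked phenyl

A few compounds are considered here, and "the series" means these few. Any claim that something is new, unique, unknown or untested is made for them only; others in the source may bear on it.

Compound 1 `COc1cc(C)cc(-c2c(-c3ccnc(-c4ccc(C(C)=O)cc4)c3)cnn2CC#N)c1` is measured in a functional assay on SF-295 cells (Homo sapiens) for cytotoxicity, read by sulforhodamine B assay, with a stated time of 48 h, tested at 1 uM (on this read-out higher numbers stand for a weaker effect at the one concentration tested and lower numbers for a stronger effect), where it gives 39%, the highest of the three numbers. Compound 2 `COc1cc(C)cc(-c2nn(CC#N)cc2-c2ccnc(-c3ccc(N(C)C)cc3)c2)c1` gives -7% in this assay, and compound 3 `Cc1cc(O)cc(-c2nn(CC#N)cc2-c2ccnc(-c3ccc(N(C)C)cc3)c2)c1` gives -5%; the step of a number 2 percentage points higher from compound 2 to compound 3 (within the scatter) shows that removing the methyl from the oxygen changes little. Compound 4 `COc1cc(C)cc(-c2c(-c3ccnc(-c4ccc(N(C)C)cc4)c3)cnn2CC#N)c1` differs from compound 1 as follows: dimethylamino in place of acetyl on an aromatic carbon. Going by the values given here, no measured step covers this exact change. Still, both compounds 2 and 3, which carry the dimethylamino group, sit far below compound 1, so a sizeable drop is expected, a number 34 percentage points lower from compound 1 to compound 4 (beyond the scatter). Compound 4 is therefore estimated to give about 5%, within a range from -20% to 30%.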

Compound 4, a percentage reported as activity, at one concentration (the size of the read-out at that concentration, not a potency): -27%
The estimate for compound 4 lay 32 percentage points above the measured number; measured number below the stated range.
By their numbers in this assay, from the lowest: compound 4; then compounds 2 and 3 (each within the scatter of the next); then compound 1.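

The direct swap from 4-acetylphenyl to 4-(dimethylamino)phenyl gives a number 66 percentage points lower from compound 1 to compound 4 (beyond the scatter) in this assay, a large step. Going by these compounds alone, the earlier compounds could not show this, since the only step among them concerned a methyl on an oxygen, whereas this pair differs only at the aromatic carbon para to a large group. Nothing available explains the size of this step.

Still open, from the compounds shown here alone, is how a primary amine, a morpholine or a carboxylic acid on this carbon would read in this assay. Going by these compounds, whether the same swap gives a similar step on other cores also stays open.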